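A few compounds are considered here, and "the series" means these few. Any claim that something is new, unique, unknown or untested is made for them only; others in the source may bear on it.

Among the measured compounds shown here, in an ADME assay on microsomes from liver (Rattus norvegicus) for metabolic stability, with a stated time of 10 min (a lower number here means that less of the compound is left, a higher number that more of the compound is left), compound 2 `COc1cc(OCc2csc(N3CCOCC3=O)n2)c2cc(-c3cn4nc(OC)sc4n3)oc2c1` gives 65%, the higher of the two numbers so far, while compound 1 `COc1cc(OCc2csc(-c3cccc(C(=O)N(C)C)c3)n2)c2cc(-c3cn4nc(OC)sc4n3)oc2c1` gives 50%. For the measured compounds named here, the single change linking them is the step of a number 15 percentage points higher from compound 1 to compound 2 (beyond the scatter), which is modest but beyond the usual scatter. Compound 3 `COc1cc(OCc2csc(-c3ccc(OC)nc3)n2)c2cc(-c3cn4nc(OC)sc4n3)oc2c1` is still unmeasured and differs from compound 2 in one group: 6-methoxypyridin-3-yl in place of 3-oxomorpholin-4-yl on an aromatic carbon. Here 6-methoxypyridin-3-yl stands in place of 3-oxomorpholin-4-yl on an aromatic carbon.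

Going by the values given here, only that one measured step bears on this change, and it has to be read backwards. Compound 1 carries 3-(dimethylcarbamoyl)phenyl at this place, also an aromatic ring, so a fall of similar size seems likely, although a single step is thin evidence. In this assay, the expected result is a number 17 percentage points lower from compound 2 to compound 3 (beyond the scatter). For compound 3, the estimate is 48%, with an expected range from 30% to 65%.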

Compound 3, percent of the compound remaining: 82%
Compound 3: the middle estimate sits 34 percentage points below what was measured; the whole stated range lies below it.
By their numbers in this assay, from the lowest: compound 1; then compound 2; then compound 3.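

Two aromatic rings at this place now fall on opposite sides of the non-aromatic 3-oxomorpholin-4-yl: the step to 6-methoxypyridin-3-yl is a number 17 percentage points higher from compound 2 to compound 3 (beyond the scatter) in this assay, so the lower number of compound 1 sets no general rule for aromatic rings here. Between the two aromatic rings the step is larger still, with a number 32 percentage points higher from compound 1 to compound 3 (beyond the scatter) for 6-methoxypyridin-3-yl in place of 3-(dimethylcarbamoyl)phenyl, so among these three compounds, which ring sits on this carbon counts for more than whether it is aromatic. No measurement at hand explains why the groups rank in this order.

The compounds shown do not separate the part of the methoxy group from that of the ring nitrogen in 6-methoxypyridin-3-yl, which a plain phenyl or a 4-methoxyphenyl ring at this place could do. As far as these compounds go, how a ring carrying an amine or a carboxylic acid would behave also stays open.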